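Replacing the aromatic ether of compound 3 with ethyl

A few compounds are considered here, and "the series" means these few. Any claim that something is new, unique, unknown or untested is made for them only; others in the source may bear on it.

In a functional assay on HeLa cells (Homo sapiens) for antiproliferative activity, read by cell counting, with a stated time of 3 days (a higher number here means a weaker inhibitor, a lower number a stronger inhibitor), compound 1 (`CC(Nc1ccccc1Oc1ccc(Cl)cc1)=C1C(=O)CC(c2ccccc2)CC1=O`) gives 500 nM, compound 2 (`COc1ccc(Oc2ccccc2NC(C)=C2C(=O)CC(c3ccccc3)CC2=O)cc1`) gives 160 nM and compound 3 (`COc1ccc(Oc2ccccc2NC(C)=C2C(=O)CC(c3ccccc3)CC2=O)cc1OC`) gives 54 nM, the lowest of the three numbers. The unmeasured compound 4 (`CCOc1ccccc1NC(C)=C1C(=O)CC(c2ccccc2)CC1=O`) has ethyl in place of 3,4-dimethoxyphenyl on an oxygen on an aromatic ring.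

Among the measured compounds shown here, three measured steps bear on this change, all modest and all made within the group that leaves: a 3.1-fold lower number from compound 1 to compound 2 (0.49 log units; beyond the scatter), a 3.0-fold lower number from compound 2 to compound 3 (0.47 log units; beyond the scatter) and a 9.3-fold lower number from compound 1 to compound 3 (0.97 log units; beyond the scatter). For the measured compounds named here, none of them removes the ring, and no compound without it has been measured, so they guide the direction only loosely. Compound 4 keeps neither methoxy, and the largest gain in the series is a 9.3-fold lower number from compound 1 to compound 3 (0.97 log units; beyond the scatter). A move to a higher number in this assay is therefore expected, larger than any measured step. The estimated step is a 37-fold higher number from compound 3 to compound 4 (1.57 log units; beyond the scatter). The estimate for compound 4 is 2000 nM, with an expected range of 300 nM to 10000 nM.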

Compound 4, half-maximal inhibitory concentration: 180 nM
The estimate for compound 4 lay 11-fold (1.05 log units) above the measured number, outside the stated range (below it).
By their numbers in this assay, from the lowest: compound 3; then compounds 2 and 4 (each within the scatter of the next); then compound 1.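

Removing the aromatic ring from this oxygen gives a 3.3-fold higher number from compound 3 to compound 4 (0.52 log units; beyond the scatter) in this assay, a modest loss for exchanging the 10 heavy atoms of 3,4-dimethoxyphenyl for the 2 of ethyl, so a ring on this oxygen is not required for activity in the nanomolar range. Ethyl also gives a 1.1-fold higher number from compound 2 to compound 4 (0.05 log units; within the scatter) and a 2.8-fold lower number from compound 1 to compound 4 (0.44 log units; beyond the scatter), so among the three aromatic groups, only 3,4-dimethoxyphenyl gives a lower number than ethyl, while 4-methoxyphenyl matches it within the scatter and 4-chlorophenyl gives a higher number. No evidence is available on what underlies these steps.

Still open, on these data alone, is how the number responds to methyl, a longer chain such as butyl, or benzyl on the same oxygen. Also open, as far as these compounds go, is whether a methoxy or dimethylamino group at the end of such a chain would lower the number further.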